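The source may hold more compounds than are shown below. What is called first, only, known or untested is meant among the compounds shown, and "the series" means these compounds.

Compound 1 `O=C(O)CC(NS(=O)(=O)c1ccc(F)cc1)c1ccccc1` was tested in a functional assay on MDA-MB-436 cells (Homo sapiens) for antiproliferative activity, read by MTT assay, with a stated time of 24 h; a higher number here means a weaker inhibitor, a lower number a stronger inhibitor. For compound 1 the assay reports only a limit, > 100000 nM, not a number. Compound 2 `O=C(O)CC(NS(=O)(=O)c1ccc(C(F)(F)F)cc1)c1ccccc1` differs from compound 1 in one place: trifluoromethyl in place of fluoro on an aromatic carbon. In this assay compound 2 gives 54700 nM, which makes the step of an at least 1.8-fold lower number from compound 1 to compound 2 (0.26 log units; that floor lies within the scatter). This step rests on a limit at one end, since (the limit of > 100000 nM in this assay, at which 2 of the 3 values shown sit).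

Compound 3 `O=C(O)CC(NC(=O)c1ccc(F)cc1)c1ccccc1F` has a different core from compound 1; how the two cores differ is not broken down here. For compound 3 the assay again reports only a limit, > 100000 nM. Compound 4 `O=C(O)CC(NC(=O)c1ccc(C(F)(F)F)cc1)c1ccccc1F`, not yet measured, differs from compound 3 by trifluoromethyl in place of fluoro on an aromatic carbon, and the surroundings of the change are the same as in the pair of compound 1 and compound 2, so it is the same change.

Since an at least 1.8-fold lower number from compound 1 to compound 2 (0.26 log units; that floor lies within the scatter) gave a step whose floor lies within the scatter, the expected step of an at least 1.1-fold lower number from compound 3 to compound 4 (0.04 log units; that floor lies within the scatter) is likewise small. Compound 4 is therefore estimated at 90000 nM in this assay, between 40000 nM and 200000 nM, with a real chance that only a limit is reported.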

Compound 4, half-maximal inhibitory concentration: 66800 nM
Compound 4: the middle estimate sits 1.3-fold (0.13 log units) above what was measured; measured number inside the range.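

In this assay, putting trifluoromethyl in place of fluoro on the second core gives an at least 1.4-fold lower number from compound 3 to compound 4 (0.17 log units; that floor lies within the scatter). Both cores give a lower number in the same direction, which is what a carried-over change would look like, but the two steps cannot be told apart in size: the same change on two cores in this assay, an at least 1.8-fold lower number (0.26 log units; that floor lies within the scatter) from compound 1 to compound 2 and an at least 1.4-fold lower number (0.17 log units; that floor lies within the scatter) from compound 3 to compound 4; the limit leaves it open whether they differ. This does not show that the change carries over with a fixed size, or that it makes a real difference on either core, as each step starts from a limit rather than a number and so gives only a floor: the limit of > 100000 nM in this assay, at which 2 of the 4 values shown sit.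

The compounds shown leave open whether another group on this aromatic carbon, such as a nitrile, a methoxy group or an amine, would change the number in this assay. They also leave open what the same swap of fluoro for trifluoromethyl would do on a core whose fluoro compound gives a true number rather than a limit.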